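Switching the aniline substituent in a sulfonamide-tailed quinazoline series

The source may hold more compounds than are shown below. What is called first, only, known or untested is meant among the compounds shown, and "the series" means these compounds.

Compound 1, `COc1cc2ncnc(Nc3cccc(Cl)c3)c2cc1OCCCCC(=O)Nc1ccc(S(N)(=O)=O)cc1`, in a functional assay on NCI-H1975 cells (Homo sapiens) for antiproliferative activity, read by MTT assay, with a stated time of 72 h (on this read-out higher numbers stand for weaker inhibition and lower numbers for stronger inhibition), gives 33200 nM.
Compound 2, `COc1cc2ncnc(Nc3ccc(F)c(Br)c3)c2cc1OCCCCC(=O)Nc1ccc(S(N)(=O)=O)cc1`, in this assay gives 31600 nM.

Both measured compounds share the same core and differ only in the group on the aromatic amine nitrogen. Among the compounds with values here, compound 2 carries the lowest of the two numbers, but its single neighbour, compound 1, sits essentially on top of it: the step of a 1.1-fold lower number from compound 1 to compound 2 (0.02 log units; within the scatter) lies within the scatter, so the two cannot be told apart.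

Compound 3 is `COc1cc2ncnc(Nc3ccc(OC(F)(F)F)cc3)c2cc1OCCCCC(=O)Nc1ccc(S(N)(=O)=O)cc1`. The change from compound 2 is 4-(trifluoromethoxy)phenyl in place of 3-bromo-4-fluorophenyl on a nitrogen on an aromatic ring; the same difference, cut one bond further out, reads (3-bromo-4-fluorophenyl)amino to (4-(trifluoromethoxy)phenyl)amino. Within the data shown here, the only measured step that bears on this position, a 1.1-fold lower number from compound 1 to compound 2 (0.02 log units; within the scatter), was flat, and it is the sole guide available. On that basis no step beyond the scatter is expected in this assay in either direction, with a wide margin kept for uncertainty.

Compound 3 is therefore estimated at 35000 nM, in the range 12000 nM to 100000 nM, which would mean an expected step of a 1.1-fold higher number from compound 2 to compound 3 (0.04 log units; within the scatter).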

Compound 3, half-maximal inhibitory concentration: 8770 nM
For compound 3 the middle estimate is 4.0-fold (0.60 log units) above the measured one; measured number outside the range, below it.
By their numbers in this assay, from the lowest: compound 3; then compounds 2 and 1 (each within the scatter of the next).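

The group on the aromatic amine nitrogen can change the result in this assay after all: 4-(trifluoromethoxy)phenyl in place of 3-bromo-4-fluorophenyl gives a 3.6-fold lower number from compound 2 to compound 3 (0.56 log units; beyond the scatter) and, in place of 3-chlorophenyl, gives a 3.8-fold lower number from compound 1 to compound 3 (0.58 log units; beyond the scatter) in the same direction. These steps are modest, but both lie beyond the scatter, so the flat result between the two halogen-bearing rings does not hold for every group at this position; among the three compounds, the lowest number belongs to the only one with an oxygen in this group. Nothing measured here accounts for the lower number of compound 3.

Because the new group differs from the earlier ones in both its atoms and its pattern on the ring, these compounds cannot show whether the trifluoromethoxy group itself matters or whether the absence of chlorine and bromine does, and an unsubstituted phenyl, a methoxyphenyl or a trifluoromethylphenyl ring would help separate the two. From the compounds shown here alone, it also remains open whether the same group would behave alike with a shorter or longer chain, or with a carboxylic acid in place of the sulfonamide.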